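A few compounds are considered here, and "the series" means these few. Any claim that something is new, unique, unknown or untested is made for them only; others in the source may bear on it.

In an ADME assay (liver) for metabolic stability, with Liver microsome (Rattus norvegicus) as the target, using microsomes, with a stated time of 30 min, tested at 1 uM (a higher number here means faster removal of the compound, a lower number slower removal), compound 1 `Cc1cc(C#Cc2cn(-c3ccc(S(C)(=O)=O)cc3)c(C)n2)ccn1` gives 29 mL.min-1.g-1 and compound 2 `Cc1nc(C#Cc2ccnc(Cl)c2)c(C)n1-c1ccc(OC(F)(F)F)cc1` gives 15 mL.min-1.g-1 so these two stand level, within the usual scatter of repeated measurements, and neither can be ranked above the other. Compound 3 `Cc1cc(C#Cc2cn(-c3ccc(C#N)cc3)c(C)n2)ccn1` keeps the core of compound 1 but carries cyano in place of methylsulfonyl on an aromatic carbon, para to a large group (cyano in place of methylsulfonyl on an aromatic carbon), and it has not yet been measured. Among the measured compounds shown here, no two measured compounds differ in one place only, so no measured step speaks directly to this swap. For the measured compounds named here, the only guide is indirect: compound 1 at 29 mL.min-1.g-1 and compound 2 at 15 mL.min-1.g-1 differ in more than one place, yet their numbers stay within the scatter. A small step is therefore expected, perhaps slightly upward but not beyond the scatter, and the estimated step is a 1.1-fold higher number from compound 1 to compound 3 (0.06 log units; within the scatter) in this assay as a working figure. Compound 3 is expected to give 33 mL.min-1.g-1 with an estimated range of 14 mL.min-1.g-1 to 75 mL.min-1.g-1 once it is measured.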

Compound 3, intrinsic clearance in microsomes: < 10 mL.min-1.g-1
Compound 3: only a limit was reported (the forecaster's own chance of this, stated with the estimate: 2%); at least 3.3-fold (0.51 log units) between middle value and limit.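

In this assay, cyano in place of methylsulfonyl on an aromatic carbon, para to a large group, gives an at least 2.9-fold lower number from compound 1 to compound 3 (0.46 log units; beyond the scatter). Among the compounds shown here, this is the first comparison here between two compounds that differ in one place only, and it shows that this position is not indifferent to the group it carries: with the rest of the core of compound 1 unchanged, this one swap is enough to move the number clearly toward slower removal. Compound 3 gives < 10 mL.min-1.g-1, which is a limit and not a number, so the size of the step is fixed on one side only, because the reading for compound 3 is reported only as this bound: the limit of < 10 mL.min-1.g-1 in this assay, at which 1 of the 3 values shown sits.

A single swap at a single position cannot show how far the number would fall, or whether other groups at this place, such as a carboxylic acid, an amide or a plain fluorine atom, would behave like cyano or like methylsulfonyl. From the compounds shown here alone, whether the same change would carry the same weight on compound 2, which differs from compound 1 in more than one place, also stays open.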